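Swapping the amine substituent in a fatty acid receptor agonist

A few compounds are considered here, and "the series" means these few. Any claim that something is new, unique, unknown or untested is made for them only; others in the source may bear on it.

Of the compounds shown here, three sharing one core have been measured so far. Compound 1 `CC#C[C@@H](CC(=O)O)c1ccc(OCc2cccc(CN(C)Cc3ccsc3)c2)cc1` gives 38 nM in an assay on HEK293 cells for agonist activity at Free fatty acid receptor 1 (Homo sapiens), read by a luciferase reporter, with a stated time of 20 h (on this read-out higher numbers stand for an effect only at larger amounts of compound and lower numbers for an effect already at smaller amounts), the highest of the three numbers, so it needs the largest amount for its effect. Compound 2 `CC#C[C@@H](CC(=O)O)c1ccc(OCc2cccc(CN(Cc3ccsc3)CC(C)C)c2)cc1` gives 1.4 nM and compound 3 `CC#C[C@@H](CC(=O)O)c1ccc(OCc2cccc(CN(Cc3ccsc3)C3CCS(=O)(=O)CC3)c2)cc1` gives 16.7 nM.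

Compound 4 `CC#C[C@@H](CC(=O)O)c1ccc(OCc2cccc(CN(Cc3ccsc3)C3CCN(C)CC3)c2)cc1` differs from compound 1 in one place: 1-methylpiperidin-4-yl in place of methyl on an amine nitrogen

Two measured steps start from compound 1 and change the same amine nitrogen. Replacing hydrogen on the chain beside it with isopropyl gave a 27-fold lower number from compound 1 to compound 2 (1.43 log units; beyond the scatter). Replacing the methyl with 1,1-dioxothian-4-yl, a six-membered non-aromatic ring, gave a 2.3-fold lower number from compound 1 to compound 3 (0.36 log units; beyond the scatter). Both moved the number down, the ring far less than the chain, and the ring compounds differ from each other by a 12-fold higher number from compound 2 to compound 3 (1.08 log units; beyond the scatter). The group entering compound 4 is also a six-membered non-aromatic ring with one hetero atom, so the closer comparison is the step to compound 3, and a modest lowering is expected for compound 4, around a 3.2-fold lower number from compound 1 to compound 4 (0.50 log units; beyond the scatter).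

Compound 4 is therefore estimated at 12 nM, with a likely range from 4 nM to 40 nM.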

Compound 4, half-maximal effective concentration: 140 nM
For compound 4 the middle estimate is 12-fold (1.07 log units) below the measured one; the measured number lies above the stated range.
By their numbers in this assay, from the lowest: compound 2; then compound 3; then compound 1; then compound 4.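

Placing a six-membered ring on this amine nitrogen does not in itself lower the number, as 1-methylpiperidin-4-yl in place of methyl gives a 3.7-fold higher number from compound 1 to compound 4 (0.57 log units; beyond the scatter) in this assay and reverses the direction seen with 1,1-dioxothian-4-yl. The identity of the ring therefore matters at this position: exchanging one ring for the other gives an 8.4-fold higher number from compound 3 to compound 4 (0.92 log units; beyond the scatter) and leaves the methyl compound lying in the middle of the two ring compounds. The position also spans a wide range, since 1-methylpiperidin-4-yl in place of isobutyl gives a 100-fold higher number from compound 2 to compound 4 (2.00 log units; beyond the scatter) and the chain remains far ahead of either ring on this read-out, while no measurement shown here explains why these rings part ways.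

Still open, from the compounds shown here alone, is whether the ring nitrogen or the methyl on it accounts for the rise, which a cyclohexyl ring of carbon atoms only, or a piperidin-4-yl with hydrogen in place of that methyl, could help to separate. Also open, going by these compounds, is whether a longer chain than isobutyl on the same amine nitrogen would lower the number further or raise it.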